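Acetyl for Bromo on a Weak Oxindole Series

The source may hold more compounds than are shown below. What is called first, only, known or untested is meant among the compounds shown, and "the series" means these compounds.

For the measured compounds named here, compound 2 `O=C1Nc2ccc(Br)cc2/C1=C/c1cccc(OCc2cn(Cc3ccccc3)nn2)c1` is the only member of the group with any reading. In a functional assay on MDA-MB-231 cells (Homo sapiens) for inhibition, read by MTT assay, with a stated time of 48 h (a lower number here means a stronger inhibitor, a higher number a weaker inhibitor), compound 2 reaches only the limit > 50000 nM, so its potency is not a number but a boundary of the measurement. It stands alone at the limit of > 50000 nM in this assay, at which 1 of the 3 values shown sits. For compound 1 `O=C1Nc2ccc(Cl)cc2/C1=C/c1cccc(OCc2cn(Cc3ccccc3)nn2)c1` this assay records "not determined" (no result reported), and for compound 3 `O=C1Nc2cc(Br)ccc2/C1=C\c1cccc(OCc2cn(Cc3ccccc3)nn2)c1` likewise "not determined" (no result reported). Compound 4 `CC(=O)c1ccc2c(c1)/C(=C/c1cccc(OCc3cn(Cc4ccccc4)nn3)c1)C(=O)N2` differs from compound 2 by acetyl in place of bromo on an aromatic carbon. Going by the values given here, no measured step in this assay guides the direction, so no shift beyond the scatter is expected from compound 2 to compound 4. Compound 4 is estimated at 50000 nM, within 8000 nM to 300000 nM, a step of a number no higher from compound 2 to compound 4 (the limit leaves the size open) that is expected to stay weak.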

Compound 4, half-maximal inhibitory concentration: > 50000 nM
Compound 4 gave a limit, no number (the forecaster's own chance of this, stated with the estimate: 60%); the middle value lies on the limit itself.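

In this assay compound 2 and compound 4 both stop at a limit, so no step can be read between them: the limit of > 50000 nM in this assay, at which 2 of the 4 values shown sit. The compounds shown leave open whether any group on that aromatic carbon gives a measurable potency.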